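The source may hold more compounds than are shown below. What is called first, only, known or untested is meant among the compounds shown, and "the series" means these compounds.

Series notes. Among the measured compounds shown here, compound 1 `COC(=O)c1ccc(NCc2cncn2Cc2ccccc2Cl)cc1-c1ccccc1` is the reference point; measured in a toxicity assay on NIH3T3 cells (Mus musculus) for cytotoxicity, read by resazurin assay (a higher number here means that more compound is needed for the effect, a lower number that less compound is needed), compound 1 gives 10000 nM, the only plain number the series holds so far. Compound 2 `Fc1ccc(Cn2cncc2CNc2ccc(-c3nc4ccccc4s3)c(-c3ccccc3)c2)c(F)c1` carries a different core and different substituents. In this assay compound 2 is reported only as a limit, > 1000 nM, not as a number. For the measured compounds named here, the second point of reference is therefore (the limit of > 1000 nM in this assay, at which 1 of the 2 values shown sits), and no step between measured compounds can be drawn from it. Compound 3 `COC(=O)c1ccc(NCc2cncn2Cc2ccc(C#N)cc2)cc1-c1ccccc1` is the next analogue to be measured in this assay. It differs from compound 1 in one place: 4-cyanophenyl in place of 2-chlorophenyl on a saturated chain carbon bound to an aromatic nitrogen. No change between the two measured compounds isolates this exchange, so there is nothing to weigh beyond the structures themselves. For a single exchange of one six-membered aromatic ring for another on a saturated chain carbon bound to an aromatic nitrogen, compound 3 is expected to stay within the scatter of compound 1. For compound 3 the expected step is no change at the digits printed from compound 1 to compound 3 (within the scatter), essentially none beyond the scatter. Compound 3 is thus estimated at 10000 nM in this assay, with a range of 4000 nM to 25000 nM.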

Compound 3, half-maximal effective concentration: > 10000 nM
Compound 3: a limit, no number; the forecaster's own chance of this, stated with the estimate: 30%; the middle value lies on the limit itself.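

Position notes. The exchange of 2-chlorophenyl for 4-cyanophenyl on a saturated chain carbon bound to an aromatic nitrogen gives, in this assay, a number no lower from compound 1 to compound 3 (the limit leaves the size open). Compound 3 stands as a limit, not a number: the limit of > 10000 nM in this assay, at which 1 of the 3 values shown sits. Among the compounds shown here, this is the first one-place comparison, and it shows that at this position the 4-cyanobenzyl group brings no lower value in this assay, which the earlier compounds could not show, although the size of the step cannot be read.

Because the exchange alters both the substituent and where it sits on the ring, the pair does not separate the loss of the chlorine from the entry of the nitrile, and a plain benzyl group at this position would stand between the two. Going by these compounds, whether any group here gives a clearly lower value in this assay also remains open, as does the effect of a carboxylic acid in place of the methyl ester on the core of compound 1.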